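Trifluoromethyl to Hydrogen: An Expected Loss in Potency

This account rests on a few compounds, and the source may have more. Where it says the series, first, only, none or still open, it means among the compounds named here.

Of the compounds shown here, three built on one shared core have been measured in an assay on isolated protein for inhibition of Polyunsaturated fatty acid 5-lipoxygenase (Homo sapiens), read by HPLC, with stated times of 15 min and 10 min; a higher number here means a weaker inhibitor, a lower number a stronger inhibitor. Compound 1 `CC(=O)c1ccc(Nc2nc(-c3ccc(F)cc3)cs2)cc1` gives 6700 nM. Compound 2 `FC(F)(F)c1ccc(Nc2nc(-c3ccc(Cl)cc3)cs2)cc1` gives 600 nM, and compound 3 `Clc1ccc(-c2csc(Nc3cc(Cl)cc(Cl)c3)n2)cc1` gives 900 nM. Compound 2 carries the lowest number of the three, yet its gap to compound 3 lies within the scatter of this kind of measurement, so the two cannot be separated; its gap to compound 1 lies beyond the scatter, so compound 1 is clearly the weaker inhibitor of that pair.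

Compound 4 `Clc1ccc(-c2csc(Nc3ccccc3)n2)cc1` has not yet been measured in this assay. It differs from compound 2 in one place: hydrogen in place of trifluoromethyl on an aromatic carbon. Going by the values given here, no measured pair in this set differs by exactly this change, so the size of the step cannot be read from the data and rests on judgment. Compound 4 is expected to be a weaker inhibitor than compound 2, with a moderate rise in the number that probably falls beyond the scatter. The step anticipated in this assay is a 3.3-fold higher number from compound 2 to compound 4 (0.52 log units; beyond the scatter). Compound 4 is therefore estimated at about 2000 nM, within a range from 700 nM to 6000 nM.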

Compound 4, half-maximal inhibitory concentration: 700 nM
Compound 4: middle estimate off by 2.9-fold (0.46 log units), on the high side; measured number inside the range.
By their numbers in this assay, from the lowest: compounds 2, 4 and 3 (each within the scatter of the next); then compound 1.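

In this assay, hydrogen in place of trifluoromethyl on an aromatic carbon, para to a large group, gives a 1.2-fold higher number from compound 2 to compound 4 (0.07 log units; within the scatter), so the two compounds cannot be told apart and this position tolerates the loss of all 4 heavy atoms of the trifluoromethyl group with no detectable change in the number. Going by these compounds alone, this is the first step in the set that isolates one change at this position: the earlier compounds differed in more than one place, so they could show only that compounds carrying different groups there gave different numbers, not what any single group contributed. No supporting measurement bears on this result, and the data give no reason for it.

The compounds shown leave open whether a group of another kind at this position, such as an amine, a carboxylic acid or a longer chain, would also leave the number unchanged. They also leave open which feature accounts for compound 1 at 6700 nM, since compound 1 differs from compound 4 in more than one place.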